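The source may report more compounds than this note shows. Statements on the series, on what has been measured and on what is new or still open speak of the compounds shown alone.

Compounds measured so far:
compound 1 `O=C(CN1CCN(c2ccccn2)CC1)Nc1cccnc1` with 2660 nM
compound 2 `Cc1cccc(NC(=O)CN2CCN(c3ccc(Cl)cn3)CC2)c1` with "not active" (no number reported)
compound 3 `CCc1cccc(NC(=O)CN2CCN(c3ccc(Cl)cn3)CC2)c1` with "not active" (no number reported)

In an assay on cells for agonist activity at D(4) dopamine receptor (Homo sapiens), read by luminescence and beta-arrestin recruitment, with a stated time of 90 min (a higher number here means that more compound is needed for the effect, a lower number that less compound is needed), compound 3 gives "not active" (no number reported), so no number stands for it, and compound 2 likewise gives "not active" (no number reported). Compound 4 `O=C(CN1CCN(c2ccc(Cl)cn2)CC1)Nc1cccnc1` differs from compound 3 by pyridin-3-yl in place of 3-ethylphenyl on an amide-type nitrogen. For the measured compounds named here, no measured step connects two compounds here, so the size of the change cannot be read from data. Compound 1 carries the same pyridin-3-yl amide and gives 2660 nM, whereas the two aryl amides gave no number, which suggests that compound 4 may regain a measurable response. Compound 4 is expected to give about 1500 nM, with a range from 300 nM to 8000 nM.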

Compound 4, half-maximal effective concentration: "not active" (no number reported)
No number was reported for compound 4, and the estimate cannot be compared.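

Compound 3 and compound 4 both report no number in this assay, so no step can be read between them. No evidence shown bears on this result. The compounds shown leave open why compound 4 stays without a number while compound 1 gives 2660 nM.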